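The source may hold more compounds than are shown below. What is called first, only, known or untested is meant among the compounds shown, and "the series" means these compounds.

Measured compounds: compound 1 `CCN1CCN(c2cc(C)c3cc(NC(=O)c4ccc(C)cc4)ccc3n2)CC1` gives 11400 nM in a functional assay on SK-BR-3 cells (Homo sapiens) for antiproliferative activity, read by MTT assay, with a stated time of 72 h; a lower number here means a stronger inhibitor, a higher number a weaker inhibitor; compound 2 `CCN1CCN(c2cc(C)c3cc(NC(=O)c4cccnc4)ccc3n2)CC1` gives 10600 nM; compound 3 `Cc1cc(NCCN2CCN(C)CC2)nc2ccc(NC(=O)c3ccc(Cl)c(Cl)c3)cc12` gives 2690 nM.

Compound 3 stands with the lowest number of the three; its nearest neighbour is compound 2, and its furthest is compound 1, both gaps lying beyond the scatter. Compound 4 `CCN1CCN(c2cc(C)c3cc(NC(=O)c4ccc(Cl)c(Cl)c4)ccc3n2)CC1` is the next compound, and it is made from compound 3 by one change: 4-ethylpiperazin-1-yl in place of (2-(4-methylpiperazin-1-yl)ethyl)amino on an aromatic carbon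

Within the data shown here, no measured step isolates this change. Among the measured compounds shown here, the only step that differs in one place, a 1.1-fold lower number from compound 1 to compound 2 (0.03 log units; within the scatter), concerns the group on the carbonyl carbon and is within the scatter. Compound 3 differs from compound 1 and compound 2 in two places at once, the group on the carbonyl carbon and the group that is exchanged here, so the two cannot be separated from the data. Given that the carbonyl-side swap moved little, the step of a 2.2-fold higher number from compound 3 to compound 4 (0.35 log units; beyond the scatter) is expected to carry most of the gap between compound 3 and the other two, though its size is uncertain. Compound 4 is therefore estimated at 6000 nM, within 2000 nM to 15000 nM.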

Compound 4, half-maximal inhibitory concentration: 2160 nM
Estimate against measurement, compound 4: 2.8-fold (0.44 log units) above; the measured number falls inside the stated range.
By their numbers in this assay, from the lowest: compounds 4 and 3 (each within the scatter of the next); then compounds 2 and 1 (each within the scatter of the next).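

In this assay, 4-ethylpiperazin-1-yl in place of (2-(4-methylpiperazin-1-yl)ethyl)amino gives a 1.2-fold lower number from compound 3 to compound 4 (0.10 log units; within the scatter), so with the 3,4-dichlorophenyl amide this position accepts the exchange of the chain-linked group for the directly attached ring. With 4-ethylpiperazin-1-yl held fixed, the group on the carbonyl carbon can now be read alone: 3,4-dichlorophenyl in place of pyridin-3-yl gives a 4.9-fold lower number from compound 2 to compound 4 (0.69 log units; beyond the scatter), and in place of 4-methylphenyl it gives a 5.3-fold lower number from compound 1 to compound 4 (0.72 log units; beyond the scatter). The compounds shown offer no independent measurement that would explain the size of these steps.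

Going by these compounds, whether the exchange at this position is equally silent with a pyridin-3-yl or 4-methylphenyl amide remains open. So does the effect of a morpholin-4-yl group or an unsubstituted piperazin-1-yl group at this position.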